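A few compounds are considered here, and "the series" means these few. Any claim that something is new, unique, unknown or untested is made for them only; others in the source may bear on it.

Compound 1 `Cc1cc(C)c(CN2CCc3c(Cl)cc([C@@H](CO)[C@@H]4CCCO4)c(Cl)c3C2=O)c(=O)[nH]1` holds the higher of the two single numbers recorded in an ADME assay on MDCK cells (Canis lupus familiaris) for permeability, read by LC-MS, with a stated time of 90 min, tested at 2 uM; a lower number here means that the compound crosses the layer more slowly, a higher number that the compound crosses the layer faster: compound 1 gives 4.3 10^-6 cm/s. Compound 3 `COc1cc(C)[nH]c(=O)c1CN1CCc2c(Cl)cc([C@@H](O)C3COC3)c(Cl)c2C1=O` gives 1.2 10^-6 cm/s in this assay, and the gap between compound 1 and compound 3 lies beyond the usual scatter of repeated measurements. Compound 2 `COC(c1cc(Cl)c2c(c1Cl)C(=O)N(Cc1c(C)cc(C)[nH]c1=O)CC2)C1CCN(C2COC2)CC1` has several entries rather than one number, giving 7 10^-6 cm/s; 7.9 10^-6 cm/s (2 entries); their spread is shown by the several entries of compound 2 in this assay, 7 10^-6 cm/s; 7.9 10^-6 cm/s (2 entries). Compound 4 `Cc1cc(C)c(CN2CCc3c(Cl)cc([C@@H](CO)[C@H]4CCCO4)c(Cl)c3C2=O)c(=O)[nH]1` keeps every atom and bond of compound 1: the two compounds have the same atoms and bonds and differ only in configuration as drawn: 1 of 2 stereo elements differ; a stereocentre at a saturated ring carbon is drawn S in compound 1 and R in compound 4. For the measured compounds named here, no measured pair here differs by such a change in configuration alone. With nothing entering or leaving, compound 4 is expected to move by no change at the digits printed from compound 1 to compound 4 (within the scatter), a step of no size beyond the scatter. Compound 4 is therefore estimated at 4.3 10^-6 cm/s, within 2.3 10^-6 cm/s to 8 10^-6 cm/s.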

Compound 4, apparent permeability: 8.5 10^-6 cm/s
The estimate for compound 4 lay 2.0-fold (0.30 log units) below the measured number, outside the stated range (above it).
By their numbers in this assay, from the lowest: compound 3; then compounds 1 and 4 (each within the scatter of the next).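

In this assay the change of configuration at the saturated ring carbon gives a 2.0-fold higher number from compound 1 to compound 4 (0.30 log units; within the scatter) and so, with every atom and bond kept, inverting this one stereocentre produces a step no larger than repeated measurements can show. For the compounds shown here, the earlier compounds held no pair differing in one place, so this is the first reading of any single change. The compounds shown leave open what inverting the second stereo element would do, and how the number would respond if a carboxylic acid replaced the hydroxyl group.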